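The compounds below may be only part of what the source reports. "The series", "measured", "known", "first", "only" and "open" are said of these compounds alone.

Three compounds share one core and differ only in the halogen pattern on the aromatic ring. Compound 1 `COC(=O)C(=O)/C=C(\O)c1cccc(Cl)c1` is the reference here. In an assay for inhibition of kynurenine 3-monooxygenase (Rattus norvegicus) (on this read-out lower numbers stand for stronger inhibition and higher numbers for weaker inhibition), compound 1 gives 1900 nM, which stands level with compound 3 and, together with it, at the low end of the three numbers. Compound 2 `COC(=O)C(=O)/C=C(\O)c1cccc(Br)c1` carries bromo in place of chloro and gives 2100 nM; the step of a 1.1-fold higher number from compound 1 to compound 2 (0.04 log units; within the scatter) is a small one. Compound 3 `COC(=O)C(=O)/C=C(\O)c1ccc(Cl)c(Cl)c1` adds a second chloro to the ring and gives 1900 nM; the step of no change at the digits printed from compound 1 to compound 3 (within the scatter) is likewise small. So neither change on the ring moved this assay beyond its scatter.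

Compound 4 `O=C(O)C(=O)/C=C(\O)c1cccc(Cl)c1` leaves the ring alone and alters the other end of the molecule: hydrogen in place of methyl on an oxygen next to a carbonyl group, that is, methoxycarbonyl becomes carboxy. Among the compounds with values here, no measured step touches this part of the structure, so the two ring steps give no guide to its direction or size. The expectation therefore rests on compound 1 alone, and a step of uncertain direction is expected, described by a 1.9-fold lower number from compound 1 to compound 4 (0.28 log units; within the scatter). Compound 4 is estimated at 1000 nM in this assay, with a wide range from 150 nM to 6000 nM.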

Compound 4, half-maximal inhibitory concentration: 320 nM
Compound 4: the middle estimate sits 3.1-fold (0.49 log units) above what was measured, within the range that was stated.
By their numbers in this assay, from the lowest: compound 4; then compounds 1, 3 and 2 (each within the scatter of the next).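

In this assay, turning methoxycarbonyl into carboxy gives a 5.9-fold lower number from compound 1 to compound 4 (0.77 log units; beyond the scatter), the only step among these compounds that lies beyond the scatter. The two halogen changes on the ring left the number within the scatter, whereas swapping one methyl for a hydrogen at the other end of the molecule does move it, so this position responds to change in a way the ring steps did not show. Nothing shown here offers a measured explanation for the step.

From the compounds shown here alone, this conclusion rests on a single pair, so it remains open whether the same change would give a similar step on the bromo compound 2 or on the compound 3 with its second chloro. Going by these compounds, it is also open whether the free carboxy group itself matters or whether other groups at this end, such as an ethyl ester or a primary amide, would give numbers closer to compound 4 or to compound 1.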